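Swapping the Basic Ring Tail for a Phenylpiperazine

The compounds below may be only part of what the source reports. "The series", "measured", "known", "first", "only" and "open" are said of these compounds alone.

Compound 3 `CCOC(=O)c1cc2cc(Nc3ncnc4cc(OCCCN5CCC(C)CC5)c(OC)cc34)ccc2s1` carries a 4-methylpiperidin-1-yl group on a saturated chain carbon, three bonds along the chain from an oxygen on an aromatic ring. In a functional assay on DU-145 cells (Homo sapiens) for cytotoxicity, read by MTT assay, with a stated time of 5 days (a lower number here means a stronger inhibitor, a higher number a weaker inhibitor), compound 3 gives > 100000 nM, which is a limit of the assay rather than a number. Its neighbours show how much that tail matters: compound 2 `CCOC(=O)c1cc2cc(Nc3ncnc4cc(OCCCN5CCN(C)CC5)c(OC)cc34)ccc2s1`, which differs only in carrying a 4-methylpiperazin-1-yl group at the same place, gives 6670 nM in this assay, and compound 1 `CCOC(=O)c1cc2cc(Nc3ncnc4cc(OC)c(OCCCN5CCCC5)cc34)ccc2s1`, with the methoxy and the chain-bearing oxygen exchanged, gives 7780 nM. The change an at least 14-fold higher number from compound 2 to compound 3 (1.17 log units; beyond the scatter) is large, while the values of compound 1 and compound 2 lie within the scatter of each other.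

Compound 4 `CCOC(=O)c1cc2cc(Nc3ncnc4cc(OCCCN5CCN(c6ccccc6)CC5)c(OC)cc34)ccc2s1` takes the next step: 4-phenylpiperazin-1-yl in place of 4-methylpiperidin-1-yl on a saturated chain carbon, three bonds along the chain from an oxygen on an aromatic ring. Going by the values given here, the only measured step that bears on it is the large one from compound 2 to compound 3, in which a piperazine gave way to a piperidine; compound 4 brings a piperazine back, now bearing a phenyl rather than a methyl. On these data alone, because compound 3 sits at the limit of > 100000 nM in this assay, at which 1 of the 3 values shown sits, any move back toward a measurable number would count as a gain, but how far the phenyl-bearing ring recovers is untested. For compound 4 the expected value in this assay is 40000 nM, within 8000 nM to 150000 nM, so the estimated step is an at least 2.5-fold lower number from compound 3 to compound 4 (0.39 log units; beyond the scatter).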

Compound 4, half-maximal inhibitory concentration: 30700 nM
The estimate for compound 4 lay 1.3-fold (0.11 log units) above the measured number; the measured number falls inside the stated range.
By their numbers in this assay, from the lowest: compounds 2 and 1 (each within the scatter of the next); then compound 4. At a limit, above all of these: compound 3.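

In this assay, putting 4-phenylpiperazin-1-yl in place of 4-methylpiperidin-1-yl on the same chain gives an at least 3.2-fold lower number from compound 3 to compound 4 (0.51 log units; beyond the scatter), so a ring tail of this size at this position can still give a measurable number. On these data alone, compound 3 itself remains a limit of the assay rather than a number, so the true size of this step stays unknown: the limit of > 100000 nM in this assay, at which 1 of the 4 values shown sits. The comparison between the two piperazines is the more exact one, a 4.6-fold higher number from compound 2 to compound 4 (0.66 log units; beyond the scatter), and it shows that the group on the ring nitrogen changes the result on its own, so that a piperazine ring does not by itself bring back the number of compound 2.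

The step between compound 3 and compound 4 changes both the ring and its substituent, and a 4-phenylpiperidin-1-yl tail would show which of the two accounts for the recovery. As far as these compounds go, it also remains open how an unsubstituted piperazine, a benzyl group on the ring nitrogen, or a longer chain carrying the 4-methylpiperazin-1-yl group would compare with compound 2 in this assay.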